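The compounds below may be only part of what the source reports. "The series", "measured", "known", "first", "only" and "open" are said of these compounds alone.

Measured in a functional assay on MDA-MB-231 cells (Homo sapiens) for inhibition, read by sulforhodamine B assay, with a stated time of 48 h; on this read-out higher numbers stand for weaker inhibition of growth and lower numbers for stronger inhibition of growth:
- compound 1 `N#Cc1c(-c2nnc(O)c3nn(-c4ccccc4)cc23)nn(-c2ccccc2)c1-c1ccccc1`: 6210 nM
- compound 2 `N#Cc1c(-c2nnc(O)c3nn(-c4ccc(Cl)cc4)cc23)nn(-c2ccccc2)c1-c1ccccc1`: > 100000 nM
- compound 3 `N#Cc1c(-c2nnc(-c3nn(-c4ccccc4)c(-c4ccccc4)c3C#N)c3nn(-c4ccc(Cl)cc4)cc23)nn(-c2ccccc2)c1-c1ccccc1`: 7900 nM

Compound 2 has no exact number and stands only at the limit of > 100000 nM in this assay, at which 1 of the 3 values shown sits. Compound 4 `N#Cc1c(-c2nnc(-c3ccccc3)c3nn(-c4ccc(Cl)cc4)cc23)nn(-c2ccccc2)c1-c1ccccc1` differs from compound 2 by phenyl in place of hydroxy on an aromatic carbon. Going by the values given here, no measured step makes this exact change. Among the compounds with values here, the one measured step, an at least 16-fold higher number from compound 1 to compound 2 (1.20 log units; beyond the scatter), is chloro in place of hydrogen on an aromatic carbon, and it shows that a single swap can move this assay a long way. Compound 3 gives a true number, 7900 nM, which suggests that a measurable value is possible. The expected change is an at least 5.0-fold lower number from compound 2 to compound 4 (0.69 log units; beyond the scatter), towards stronger inhibition of growth, though its size is uncertain. For compound 4 the estimated value is 20000 nM, with an expected range from 4000 nM to 100000 nM.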

Compound 4, concentration for 50% growth inhibition: 6420 nM
The estimate for compound 4 lay 3.1-fold (0.49 log units) above the measured number; the measured number falls inside the stated range.
By their numbers in this assay, from the lowest: compounds 1, 4 and 3 (each within the scatter of the next). At a limit, above all of these: compound 2.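

Swapping hydroxy for phenyl on this aromatic carbon, next to the ring nitrogen, gives an at least 15-fold lower number from compound 2 to compound 4 (1.19 log units; beyond the scatter). Compound 4 keeps the chloro, so the loss of measurable inhibition that came with chloro is not fixed: a change at this second place brings a measurable value back. Compound 2 stands only at a limit, so the true size of this step is unknown: the limit of > 100000 nM in this assay, at which 1 of the 4 values shown sits.

As far as these compounds go, what remains open is whether the gain needs an aromatic ring here or only the loss of hydroxy. An amine, a methyl or a methoxy group at this place would help separate the two.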